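A few compounds are considered here, and "the series" means these few. Any claim that something is new, unique, unknown or untested is made for them only; others in the source may bear on it.

Among the measured compounds shown here, compound 3 `Cc1nc2c(OCc3ccccc3)cccn2c1CS(C)(=O)=O` stands highest of the three compounds measured so far in a functional assay on the whole organism with Rattus norvegicus as the target, with a stated time of 4 h, at a dose of 40 mg/kg by the intraperitoneal route (a higher number here means more inhibition at the dose given (going by the name of the read-out), a lower number less inhibition), where compound 3 gives 61%. Compound 1 `Cc1nc2c(OCc3ccccc3)cccn2c1CCC#N` gives 40% in this assay, and compound 2 `CSCc1c(C)nc2c(OCc3ccccc3)cccn12` gives 29%. Two measured steps lead into compound 3: a number 21 percentage points higher from compound 1 to compound 3 (beyond the scatter), and a number 32 percentage points higher from compound 2 to compound 3 (beyond the scatter). The remaining step, a number 11 percentage points lower from compound 1 to compound 2 (beyond the scatter), is smaller.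

Compound 4 `CC(=O)OCc1c(C)nc2c(OCc3ccccc3)cccn12` differs from compound 3 in one place: acetoxy in place of methylsulfonyl on a saturated chain carbon bound to an aromatic carbon. The two steps that end at compound 3 both bear on this, since each put a methylsulfonyl at this place and each raised inhibition, by a modest and a large amount. Taking the methylsulfonyl away again for an acetoxy, a group not seen in any measured compound here, is therefore expected to undo part of that gain: the step of a number 21 percentage points lower from compound 3 to compound 4 (beyond the scatter) is the expected size, a drop beyond the scatter. Compound 4 is expected to give about 40% in this assay, with a likely range from 20% to 60%.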

Compound 4, a percentage reported as inhibition, in the whole organism at one dose (the size of the read-out at that dose, not a potency): 88%
Compound 4: middle estimate off by 48 percentage points, on the low side, outside the stated range (above it).
By their numbers in this assay, from the lowest: compound 2; then compound 1; then compound 3; then compound 4.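

At this saturated chain carbon bound to an aromatic carbon, methylsulfonyl does not give the highest number in this assay, since acetoxy gives a number 27 percentage points higher from compound 3 to compound 4 (beyond the scatter) even though both groups have 4 heavy atoms and 2 hydrogen-bond acceptors, so those counts do not separate them. The gaps to the other two groups are larger, with a number 59 percentage points higher from compound 2 to compound 4 (beyond the scatter) and a number 48 percentage points higher from compound 1 to compound 4 (beyond the scatter), which shows how far a change at this one place can move inhibition among these four compounds. Nothing available here accounts for the acetoxy result.

Still open, going by these compounds, is whether a hydroxyl, an amide or a longer ester such as propionyloxy at this place would keep inhibition as high. These are readings at one dose and one time, so they do not tell how the compounds rank in potency.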